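A few compounds are considered here, and "the series" means these few. Any claim that something is new, unique, unknown or untested is made for them only; others in the source may bear on it.

Compounds measured in an assay on isolated protein for inhibition of protein deacetylase HDAC6 (Homo sapiens); a higher number here means a weaker inhibitor, a lower number a stronger inhibitor:
compound 1 `COc1cc(C(=O)c2ccc3c(ccn3S(=O)(=O)c3ccc(/C=C/C(=O)NO)cc3)c2)cc(OC)c1OC`, 972 nM
compound 2 `COc1ccc(C(=O)c2ccc3c(ccn3S(=O)(=O)c3ccc(/C=C/C(=O)NO)cc3)c2)cc1`, 848 nM
compound 3 `COc1ccc(C(=O)c2ccc3c(ccn3Cc3ccc(C(=O)NO)cc3)c2)cc1OC`, 15.5 nM

Among these three numbers compound 3 stands lowest. Its nearest neighbour, compound 2, gives 848 nM in this assay, and compound 1 gives 972 nM; both gaps lie well beyond the scatter. Compound 4 `O=C(NO)c1ccc(Cn2ccc3cc(C(=O)c4ccc(F)cc4)ccc32)cc1` has not yet been measured. It differs from compound 3 in one place: 4-fluorophenyl in place of 3,4-dimethoxyphenyl on a carbonyl carbon. Within the data shown here, one measured step bears on this change: a 1.1-fold lower number from compound 1 to compound 2 (0.06 log units; within the scatter), which likewise exchanges one aromatic ring for another on the carbonyl carbon. That step stayed within the scatter. Among the measured compounds shown here, the comparison is indirect, since compound 1 and compound 2 share a core that differs from the core of compound 3, and no step between compound 2 and compound 3 has been worked out here. For compound 4 the estimated step is therefore a 1.3-fold higher number from compound 3 to compound 4 (0.11 log units; within the scatter), nothing beyond the scatter. Compound 4 is expected to give 20 nM in this assay, with a range from 8 nM to 50 nM.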

Compound 4, half-maximal inhibitory concentration: 9.25 nM
For compound 4 the middle estimate is 2.2-fold (0.33 log units) above the measured one; the range from low to high includes it.
By their numbers in this assay, from the lowest: compounds 4 and 3 (each within the scatter of the next); then compounds 2 and 1 (each within the scatter of the next).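

On the core of compound 3, 4-fluorophenyl in place of 3,4-dimethoxyphenyl on the carbonyl carbon gives a 1.7-fold lower number from compound 3 to compound 4 (0.22 log units; within the scatter) in this assay, so this position accepts a ring with fewer heavy atoms and no hydrogen-bond acceptors without a change beyond the scatter. Among these compounds, the earlier step at this carbonyl carbon, a 1.1-fold lower number from compound 1 to compound 2 (0.06 log units; within the scatter), came from a different core and exchanged only one methoxy-bearing ring for another, whereas this exchange removes the methoxy groups altogether. No measurement shown here accounts for the two rings reading alike.

From the compounds shown here alone, it remains open whether an amine or a carboxylic acid on this ring, or a longer chain in its place on the carbonyl carbon, would also stay within the scatter. Going by these compounds, whether 4-fluorophenyl would behave the same way on the core of compound 1 also remains open.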